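A few compounds are considered here, and "the series" means these few. Any claim that something is new, unique, unknown or untested is made for them only; others in the source may bear on it.

Among the compounds with values here, in a functional assay on A2780 cells (Homo sapiens) for inhibition, read by sulforhodamine B assay, with a stated time of 72 h (a lower number here means a stronger inhibitor, a higher number a weaker inhibitor), compound 1 (`O=C(NCc1ccc(S(=O)(=O)c2ccccc2)cc1)c1c[nH]c2ccncc12`) gives 2100 nM, the only true number so far. From the compounds shown here alone, compound 2 (`O=C(NCc1ccc(S(=O)(=O)N2CCCCC2)cc1)c1ccn2ccnc2c1`) reads > 10000 nM, which is a limit of the assay and not a number, so its real position is unknown. Compound 3 (`O=C(NCc1ccc(S(=O)(=O)N2CCCCC2)cc1)c1cc2ccncc2o1`) keeps the amide and the piperidine sulfonyl part of compound 2, and the change sits on a carbonyl carbon: a group of 9 heavy atoms (7 carbon, 1 nitrogen, 1 oxygen; one five-membered aromatic ring with 1 hetero atom, one six-membered aromatic ring with 1 hetero atom) in place of a group of 9 heavy atoms (7 carbon, 2 nitrogen; one five-membered aromatic ring with 2 hetero atoms, one six-membered aromatic ring with 1 hetero atom), on a carbonyl carbon. Within the data shown here, no measured step covers this kind of exchange, so the expectation is loose. Compound 1, with a different ring group on the carbonyl carbon, reaches 2100 nM, which shows that a measurable value is possible in this set. A move to a lower number in this assay, beyond the scatter, is expected, and the estimated step is an at least 50-fold lower number from compound 2 to compound 3 (1.69 log units; beyond the scatter). For compound 3 the estimated value is 200 nM, with an expected range of 20 nM to 3000 nM.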

Compound 3, half-maximal inhibitory concentration: 29 nM
The estimate for compound 3 lay 6.9-fold (0.84 log units) above the measured number; measured number inside the range.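

In this assay, with the amide and the piperidine sulfonyl part held constant, the exchange on the carbonyl carbon gives an at least 340-fold lower number from compound 2 to compound 3 (2.53 log units; beyond the scatter), so this position alone can carry a large change. The two groups have the same counts of heavy atoms, hydrogen-bond donors and hydrogen-bond acceptors, and differ in a ring nitrogen against a ring oxygen, so those counts do not separate this pair. Compound 2 reads as a limit and not a number, so the step gives only a minimum size: the limit of > 10000 nM in this assay, at which 1 of the 3 values shown sits.

Compound 1 differs from compound 3 in more than one place, so the separate contributions of its ring group and its sulfonyl part cannot be read. From the compounds shown here alone, whether an amine or a carboxylic acid on the group at the carbonyl carbon, or a morpholine in place of the piperidine, would retain the value of compound 3 remains open.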